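A Mirror-Image Change on a Weak Sodium Channel Binder

The compounds below may be only part of what the source reports. "The series", "measured", "known", "first", "only" and "open" are said of these compounds alone.

Compound 3 `N[C@@H](COc1ccc(Cl)cc1)c1ccccc1` was tested in an assay on isolated protein for inhibition of sodium channel protein type 4 subunit alpha (Homo sapiens) (on this read-out higher numbers stand for an effect only at larger amounts of compound and lower numbers for an effect already at smaller amounts), where compound 3 gives 10000 nM. Compound 1 `Cc1cccc(C)c1NC(=O)[C@@H](C)NCc1ccccc1` gives 11200 nM, and compound 2 `Cc1cc(Cl)ccc1OC[C@H](N)c1ccccc1` gives 15100 nM; compound 3 shows the lowest number of the three, but all three sit within the usual scatter of one another. Within the data shown here, the only measured single change, a 1.5-fold lower number from compound 2 to compound 3 (0.18 log units; within the scatter), concerns hydrogen in place of methyl on an aromatic carbon. Compound 4 `N[C@H](COc1ccc(Cl)cc1)c1ccccc1` differs from compound 3 in another way: the two compounds have the same atoms and bonds and differ only in configuration as drawn: 1 of 1 stereo elements differ; a stereocentre at a saturated chain carbon is drawn R in compound 3 and S in compound 4. Among the measured compounds shown here, no measured step involves a change of configuration, so nothing here shows how large such a change can be, and the three measured numbers lie close together. The step from compound 3 to compound 4 is therefore expected to be a 1.2-fold higher number from compound 3 to compound 4 (0.08 log units; within the scatter), with no change beyond the scatter. Compound 4 is estimated at 12000 nM, within a range from 4000 nM to 40000 nM.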

Compound 4, half-maximal effective concentration: 3020 nM
Compound 4: the middle estimate sits 4.0-fold (0.60 log units) above what was measured; the whole stated range lies above it.
By their numbers in this assay, from the lowest: compound 4; then compounds 3, 1 and 2 (each within the scatter of the next).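

In this assay, among these compounds, the configuration at this saturated chain carbon proves to matter: the mirror-image change gives a 3.3-fold lower number from compound 3 to compound 4 (0.52 log units; beyond the scatter), whereas the only earlier step, hydrogen in place of methyl on an aromatic carbon, stayed within the scatter. The shift can be traced to configuration alone because nothing else changes: the fact that compounds 3 and 4 differ only in the configuration as drawn.

The compounds shown leave open whether the same change of configuration would act alike on compound 2, which carries the additional methyl. They also leave open whether it would hold with a nitrile in place of the chlorine.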